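The source may report more compounds than this note shows. Statements on the series, on what has been measured and on what is new or still open speak of the compounds shown alone.

Compound 3 `COc1ccc(-n2cc(COc3ccc(/C=N/Nc4nc(-c5ccc(Cl)cc5)cs4)cc3)nn2)cc1` is one of three close analogues whose toxicity toward a human monocytic cell line has been measured. In an ADME assay on THP-1 cells (Homo sapiens) for cytotoxicity (on this read-out higher numbers stand for lower toxicity in this test and lower numbers for higher toxicity in this test), compound 3 gives 38700 nM, the highest of the three numbers, though its two neighbours sit within the scatter of it. Compound 1 `COc1ccc(-n2cc(COc3ccc(/C=N/Nc4nc(-c5cc6cccc(OC)c6oc5=O)cs4)cc3)nn2)cc1` gives 34500 nM in this assay, and compound 2 `COc1ccc(-n2cc(COc3ccc(/C=N/Nc4nc(-c5ccc([N+](=O)[O-])cc5)cs4)cc3)nn2)cc1` gives 37900 nM. For the measured compounds named here, the one single-point step among them, a 1.0-fold higher number from compound 2 to compound 3 (0.01 log units; within the scatter), therefore shows nothing beyond the scatter, and the numbers of compound 1 and compound 3 likewise lie within the scatter of each other.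

Compound 4 `COc1ccc(-n2cc(COc3ccc(/C=N/Nc4nc(-c5ccc(-c6ccccc6)cc5)cs4)cc3)nn2)cc1` has not yet been measured. It differs from compound 3 by phenyl in place of chloro on an aromatic carbon. Going by the values given here, no measured step covers this kind of exchange; the only step available, from nitro to chloro, was flat, and the three compounds as a whole vary little whatever group sits on that ring. On this basis compound 4 is expected to stay close to compound 3, with a 1.1-fold lower number from compound 3 to compound 4 (0.03 log units; within the scatter) foreseen as no step beyond the scatter in either direction. Compound 4 is thus estimated to give 36000 nM in this assay, within a range from 15000 nM to 75000 nM.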

Compound 4, half-maximal cytotoxic concentration: 35800 nM
Estimate against measurement, compound 4: 1.0-fold (0.00 log units) above, within the range that was stated.
By their numbers in this assay, from the lowest: compounds 1, 4, 2 and 3 (each within the scatter of the next).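

Replacing the single chlorine of the 4-chlorophenyl group with a whole phenyl adds a six-membered aromatic ring of carbon only, yet in this assay the change gives a 1.1-fold lower number from compound 3 to compound 4 (0.03 log units; within the scatter) and stays within the scatter. The exchange of nitro for phenyl at the same aromatic carbon gives a 1.1-fold lower number from compound 2 to compound 4 (0.02 log units; within the scatter) and also stays within the scatter. The earlier compounds had shown only that nitro and chloro read alike at this place, para to a large group, whereas these steps extend that flat reading to a far bulkier group of six heavy atoms, although no measurement among the data accounts for the flatness.

Going by these compounds, whether an amine, a carboxylic acid or a longer alkyl chain on this aromatic carbon would move the number beyond the scatter remains open, as does the effect of changes elsewhere on the shared core. On these data alone, all of these numbers also come from a single human cell line, so it remains open whether the same flat reading would hold in other cells.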